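From 4-hydroxyphenyl to 3-hydroxyphenyl: compound 2 and compound 3

The source may hold more compounds than are shown below. What is called first, only, known or untested is meant among the compounds shown, and "the series" means these compounds.

Values so far in a functional assay on HepG2 cells (Homo sapiens) for inhibition, read by MTT assay, with a stated time of 24 h (a higher number here means a weaker inhibitor, a lower number a stronger inhibitor), are as follows.
Compound 1 `CC1(C)[C@H]2CC[C@]1(C)N(Cc1cn(-c3ccccc3C#N)nn1)C(=O)C2` gives 180 nM as its value
Compound 2 `CC1(C)[C@H]2CC[C@]1(C)N(Cc1cn(-c3ccc(O)cc3)nn1)C(=O)C2` gives 80 nM as its value

Compound 2 holds the lower of the two numbers and is the stronger inhibitor of the pair, with compound 1 as its nearest neighbour. Compound 3 `CC1(C)[C@H]2CC[C@]1(C)N(Cc1cn(-c3cccc(O)c3)nn1)C(=O)C2` has the same atoms as compound 2 joined differently: 3-hydroxyphenyl in place of 4-hydroxyphenyl on an aromatic nitrogen with the rest of the structure unchanged. For the measured compounds named here, only one measured step bears on this change, and it is modest: a 2.3-fold lower number from compound 1 to compound 2 (0.35 log units; beyond the scatter) with 4-hydroxyphenyl in place of 2-cyanophenyl. Going by the values given here, that step swaps one group for a different one, so no measured pair isolates the change made here. Among the compounds with values here, the expected change in this assay is small and probably within the scatter, with a lean to a higher number, as compound 2 at 80 nM is the lower of only two values. The estimate means a 1.5-fold higher number from compound 2 to compound 3 (0.18 log units; within the scatter) as the expected step. Compound 3 is estimated at 120 nM with a range of 50 nM to 280 nM expected for the coming measurement.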

Compound 3, half-maximal inhibitory concentration: 70 nM
The estimate for compound 3 lay 1.7-fold (0.23 log units) above the measured number; measured number inside the range.
By their numbers in this assay, from the lowest: compounds 3 and 2 (each within the scatter of the next); then compound 1.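

In this assay, for the compounds shown here, 3-hydroxyphenyl in place of 4-hydroxyphenyl on an aromatic nitrogen gives a 1.1-fold lower number from compound 2 to compound 3 (0.06 log units; within the scatter) and so does not separate the two hydroxyphenyl groups; this is the first measured pair to isolate that change, and the read-out tolerates either arrangement. Against the 2-cyanophenyl group of compound 1, 3-hydroxyphenyl gives a 2.6-fold lower number from compound 1 to compound 3 (0.41 log units; beyond the scatter) and 4-hydroxyphenyl gives a 2.3-fold lower number from compound 1 to compound 2 (0.35 log units; beyond the scatter), so the gap to compound 1 appears with both hydroxyphenyl groups and does not depend on which of the two is present. No supporting measurement is available to explain either the absence of a difference between compound 2 and compound 3 or the gap to compound 1.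

Still open, as far as these compounds go, is whether the hydroxyl group itself accounts for that gap, or whether the nitrile of compound 1 alone sets it apart. A plain phenyl on the aromatic nitrogen, or a methoxy group or an amine in place of the hydroxyl, would bear on that question, and the three compounds shown cannot settle it.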